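Carboxy in place of trifluoromethyl: solubility expected

The source may hold more compounds than are shown below. What is called first, only, known or untested is meant among the compounds shown, and "the series" means these compounds.

Compound 1 `COc1ccc(-c2cc(-c3ccc(S(N)(=O)=O)cc3)cnc2N)cn1` gives > 100 ug/mL in a physicochemical assay for solubility, read by nephelometry, measured as kinetic solubility, at pH 2 (on this read-out higher numbers stand for higher solubility and lower numbers for lower solubility), which is a limit of the assay rather than a number.
Compound 2 `COc1ccc(-c2cc(-c3ccc(C(F)(F)F)cc3)cnc2N)cn1` gives > 100 ug/mL in this assay, likewise a limit.

Compound 2 therefore stands at the limit, as summarised by the limit of > 100 ug/mL in this assay, at which 2 of the 2 values shown sit. Within the data shown here, the only measured step, a step that the two limits leave unreadable from compound 1 to compound 2, cannot be sized for that reason. Compound 3 `COc1ccc(-c2cc(-c3ccc(C(=O)O)cc3)cnc2N)cn1` differs from compound 2 by carboxy in place of trifluoromethyl on an aromatic carbon. No readable step exists to set a direction. Compound 3 is expected to stay close to the limit, an estimated step of a number no higher from compound 2 to compound 3 (the limit leaves the size open). Compound 3 is estimated at 100 ug/mL, within 30 ug/mL to 200 ug/mL.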

Compound 3, solubility: 12.5 ug/mL
Compound 3: middle estimate off by 8.0-fold (0.90 log units), on the high side; measured number below the stated range.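

At this position, on an aromatic carbon para to a large group, the choice of group can clearly move the read-out in this assay. Carboxy in place of trifluoromethyl gives an at least 8.0-fold lower number from compound 2 to compound 3 (0.90 log units; beyond the scatter), and carboxy in place of sulfamoyl gives an at least 8.0-fold lower number from compound 1 to compound 3 (0.90 log units; beyond the scatter). The earlier pair could show no such difference, and the sizes of both new steps remain open-ended, as the starting compounds sit at a limit: the limit of > 100 ug/mL in this assay, at which 2 of the 3 values shown sit.

As far as these compounds go, how far compound 1 and compound 2 lie past that limit remains open. So does how a methyl ester or an amine at this position would read.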